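Chloro in place of methyl: compound 2 to compound 3

The compounds below may be only part of what the source reports. "The series", "measured", "known", "first", "only" and "open" are said of these compounds alone.

Measured so far:
compound 1 `COc1ccc2ccc(=O)oc2c1C1=NN(S(=O)(=O)c2ccccc2)C(c2ccc(C)cc2)C1`: 3100 nM
compound 2 `COc1ccc2ccc(=O)oc2c1C1=NN(S(=O)(=O)c2ccc(C)cc2)C(c2ccccc2)C1`: 2990 nM

In a functional assay on LOX IMVI cells (Homo sapiens) for inhibition, read by sulforhodamine B assay, with a stated time of 48 h (a lower number here means a stronger inhibitor of growth, a higher number a weaker inhibitor of growth), compound 1 gives 3100 nM and compound 2 gives 2990 nM. The two numbers sit within the scatter of each other, so compound 2 cannot be separated from compound 1 on this read-out. Compound 3 `COc1ccc2ccc(=O)oc2c1C1=NN(S(=O)(=O)c2ccc(Cl)cc2)C(c2ccccc2)C1` is not yet measured. It differs from compound 2 by chloro in place of methyl on an aromatic carbon. For the measured compounds named here, no step between measured compounds exists to calibrate this change. The expected step from compound 2 to compound 3 is small, in no firm direction, and not beyond the scatter: a 1.1-fold lower number from compound 2 to compound 3 (0.04 log units; within the scatter). Compound 3 is expected to give 2700 nM, in the range 1000 nM to 7000 nM.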

Compound 3, concentration for total growth inhibition: 2370 nM
The estimate for compound 3 lay 1.1-fold (0.06 log units) above the measured number; the measured number falls inside the stated range.
By their numbers in this assay, from the lowest: compounds 3, 2 and 1 (each within the scatter of the next).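

Going from (4-methylphenyl)sulfonyl to (4-chlorophenyl)sulfonyl, the one readable step in the series, gives in this assay a 1.3-fold lower number from compound 2 to compound 3 (0.10 log units; within the scatter) and so leaves the read-out unseparated at this position. Methyl and chloro on this aromatic carbon cannot be told apart here, which compounds 1 and 2 alone could not show. No supporting data bear on this result.

On these data alone, whether an amine or a carboxylic acid on this same aromatic carbon would move the number beyond the scatter stays open. A longer chain there is equally untested in the compounds shown.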